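Swapping bromo for cyano at the far end of compound 3

This account rests on a few compounds, and the source may have more. Where it says the series, first, only, none or still open, it means among the compounds named here.

Of the compounds shown here, three sharing one core have been tested in a functional assay on Raji cells (Homo sapiens) for cytotoxicity, read by CCK-8 assay, with a stated time of 24 h; on this read-out higher numbers stand for weaker inhibition and lower numbers for stronger inhibition. Compound 1 `C=CC(=O)N1C(=O)CC(c2ccccc2Cl)Sc2ccccc21` gives 50400 nM, compound 2 `C=CC(=O)N1C(=O)CC(c2ccc(Cl)cc2)Sc2ccccc21` gives 18400 nM, and compound 3 `C=CC(=O)N1C(=O)CC(c2ccc(Br)cc2)Sc2ccccc21` gives 51300 nM. Compound 3 thus has the highest number of the three, though its gap to compound 1 lies within the scatter; only its gap to compound 2, a 2.8-fold higher number from compound 2 to compound 3 (0.45 log units; beyond the scatter), is beyond it. Compound 4 `C=CC(=O)N1C(=O)CC(c2ccc(C#N)cc2)Sc2ccccc21` differs from compound 3 as follows: cyano in place of bromo on an aromatic carbon. Among the compounds with values here, the one measured step that bears on this is the swap of one substituent for another on the same aromatic carbon, a 2.8-fold higher number from compound 2 to compound 3 (0.45 log units; beyond the scatter), a modest move; the other steps, a 2.7-fold lower number from compound 1 to compound 2 (0.44 log units; beyond the scatter) and a 1.0-fold higher number from compound 1 to compound 3 (0.01 log units; within the scatter), change where the group sits rather than what it is. Within the data shown here, no step from bromo to cyano has been measured, so only a step of similar modest size, in either direction, is a reasonable expectation in this assay. Compound 4 is therefore expected to give 30000 nM, within 9000 nM to 100000 nM, meaning an expected step of a 1.7-fold lower number from compound 3 to compound 4 (0.23 log units; within the scatter).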

Compound 4, half-maximal inhibitory concentration: 84500 nM
Beside the measured number, compound 4's estimate is 2.8-fold (0.45 log units) below it; the range from low to high includes it.
By their numbers in this assay, from the lowest: compound 2; then compounds 1, 3 and 4 (each within the scatter of the next).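

In this assay, swapping bromo for cyano on this aromatic carbon leaves the number within the scatter (a 1.6-fold higher number from compound 3 to compound 4 (0.22 log units; within the scatter)), and replacing the whole 2-chlorophenyl group with 4-cyanophenyl also stays within it (a 1.7-fold higher number from compound 1 to compound 4 (0.22 log units; within the scatter)). Chloro on the same carbon now stands apart from two other groups rather than one, with cyano in its place giving a step beyond the scatter (a 4.6-fold higher number from compound 2 to compound 4 (0.66 log units; beyond the scatter)). No measurement shown here accounts for chloro differing from both bromo and cyano.

The compounds shown leave open whether an amine, a carboxylic acid or a methyl group on this carbon would give a number near that of chloro or near those of bromo and cyano. They also leave open how cyano would behave elsewhere on this aromatic ring.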